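This account rests on a few compounds, and the source may have more. Where it says the series, first, only, none or still open, it means among the compounds named here.

In a functional assay on HL-60 cells (Homo sapiens) for inhibition, read by CCK-8 assay, with a stated time of 48 h, tested at 20 uM (on this read-out higher numbers stand for more inhibition of growth at the one concentration tested and lower numbers for less inhibition of growth), compound 1 (`COc1ccc(Cc2nnc(NC(=O)/C(C#N)=C/c3ccccc3OS(=O)(=O)c3ccc(OC)cc3)s2)cc1`) gives 100%, while compound 2 (`Cc1ccc(S(=O)(=O)Oc2ccccc2/C=C(\C#N)C(=O)Nc2nnc(Cc3cccc4ccccc34)s2)cc1`) gives 19%, the lower of the two numbers and a gap beyond the scatter. Compound 3 (`COc1ccc(S(=O)(=O)Oc2ccccc2/C=C(\C#N)C(=O)Nc2nnc(Cc3cccc4ccccc34)s2)cc1`) has not yet been measured. It keeps the rest of compound 2 and changes one group: methoxy in place of methyl on an aromatic carbon, para to a large group. For the measured compounds named here, no two measured compounds differ in one place only, so this change has not been seen on its own. Compound 1 also carries the (4-methoxyphenyl)sulfonyl group and gives 100%, though it differs elsewhere too. The expected step is therefore a modest rise, estimated as a number 15 percentage points higher from compound 2 to compound 3 (beyond the scatter) in this assay. For compound 3 the expected value is 34%, within an estimated range of 10% to 70%.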

Compound 3, percent growth inhibition at one concentration: 98%
Beside the measured number, compound 3's estimate is 64 percentage points below it; the whole stated range lies below it.
By their numbers in this assay, from the lowest: compound 2; then compounds 3 and 1 (each within the scatter of the next).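

Seen on its own for the first time, methoxy in place of methyl on the aromatic carbon para to a large group gives a number 79 percentage points higher from compound 2 to compound 3 (beyond the scatter) in this assay, so this single place has a large effect on growth inhibition at the one concentration tested. With the (4-methoxyphenyl)sulfonyl group present, naphthalen-1-yl in place of 4-methoxyphenyl on the chain gives a number 2 percentage points lower from compound 1 to compound 3 (within the scatter), so this second change shows no effect beyond the scatter in this pair. No measurement here explains why the first step is so large.

The compounds shown leave open what an ethoxy group, a hydroxyl group or an amine would give in place of the methoxy group. They also leave open whether the step from methyl to methoxy has the same size with 4-methoxyphenyl on the chain.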